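Swapping tert-butyl for cyclopropyl on the shared core

The source may report more compounds than this note shows. Statements on the series, on what has been measured and on what is new or still open speak of the compounds shown alone.

Measured in an ADME assay on microsomes from liver (Homo sapiens) for metabolic stability, read by LC-MS, using NADPH, with a stated time of 10 min, tested at 10 uM (a higher number here means that the compound lasts longer, a lower number that the compound disappears faster), as follows
Compound 1 `CC(C)(C)n1nc(Oc2cc(Cl)ccn2)c2c(N)ncnc21` gives 1 h
Compound 2 `CO[C@H]1CC[C@H](n2nc(Oc3cc(C(F)(F)F)ccn3)c3c(N)ncnc32)CC1` gives > 2.41 h as a limit, not a number
Compound 3 `CC(C)(C)n1nc(Oc2cc(O)ccn2)c2c(N)ncnc21` gives 1.4 h

Among the measured compounds shown here, compound 1 sits at 1 h in this assay and its only close neighbour comes with hydroxy in place of chloro on an aromatic carbon, which gives a 1.4-fold higher number from compound 1 to compound 3 (0.15 log units; within the scatter) and so no real change. Compound 4 `Nc1ncnc2c1c(Oc1cc(Cl)ccn1)nn2C1CC1` keeps the core of compound 1 but carries cyclopropyl in place of tert-butyl on an aromatic nitrogen. For the measured compounds named here, that one measured step concerns a different group, and no measured step changes tert-butyl alone, so the data give no direct size for this swap. A step beyond the scatter in this assay is therefore not expected, in either direction. The estimated step is a 1.1-fold higher number from compound 1 to compound 4 (0.04 log units; within the scatter) on this reading. For compound 4 the expected half-life is 1.1 h with an estimated range from 0.5 h to 2.4 h as the upper end.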

Compound 4, half-life: 1.05 h
Compound 4: middle estimate off by 1.0-fold (0.02 log units), on the high side, and the stated range covers the measured number.
By their numbers in this assay, from the lowest: compounds 1, 4 and 3 (each within the scatter of the next). At a limit, above all of these: compound 2.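

On the aromatic nitrogen, cyclopropyl in place of tert-butyl now has a measured size in this assay: a 1.1-fold higher number from compound 1 to compound 4 (0.02 log units; within the scatter), so this change in the group leaves the half-life without real change while chloro stays in place. The earlier compounds shown here gave no step at this position with all else held fixed. Nothing shown here explains why the two groups read alike.

Still open, from the compounds shown here alone, is how a longer chain or an amine on this nitrogen would read. Going by these compounds, whether cyclopropyl gives the same result with hydroxy in place of chloro also remains unknown.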